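Adding a Phenyl Group to a Ring Amine Side Chain

The source may report more compounds than this note shows. Statements on the series, on what has been measured and on what is new or still open speak of the compounds shown alone.

Four compounds share one core and differ only in the group attached through the amide. Compound 1 `Cc1ccccc1-n1cc(CNC(=O)[C@@H](N)CCSC[C@H]2O[C@@H](n3cnc4c(N)ncnc43)[C@H](O)[C@@H]2O)cn1` is recorded as "not determined" (no result reported) in an assay on Sf9 cells for inhibition of histone-lysine N-methyltransferase EZH2 variant Y641N (Homo sapiens), read by scintillation counting, in the presence of a further agent that is not named here (a lower number here means a stronger inhibitor, a higher number a weaker inhibitor), and compound 3 `CN1CCn2nc(CNC(=O)[C@@H](N)CCSC[C@H]3O[C@@H](n4cnc5c(N)ncnc54)[C@H](O)[C@@H]3O)cc2C1` likewise as "not determined" (no result reported), so compound 3 stands without a number, as does compound 1. Going by the values given here, compound 2 `Nc1ncnc2c1ncn2[C@@H]1O[C@H](CSCC[C@H](N)C(=O)NCc2cnn(-c3ccc(F)cc3)c2)[C@@H](O)[C@H]1O` gives 600 nM in this assay, the only measured value in this set. Compound 4 `Nc1ncnc2c1ncn2[C@@H]1O[C@H](CSCC[C@H](N)C(=O)NCc2cc3n(n2)CCN(Cc2ccccc2)C3)[C@@H](O)[C@H]1O` arises from compound 3 by phenyl in place of hydrogen on a saturated chain carbon bound to an amine nitrogen in a ring. Among the compounds with values here, no measured pair shows the effect of such a change, so the direction and size of the step from compound 3 to compound 4 cannot be read from the data. Within the data shown here, the only anchor is compound 2 at 600 nM. Compound 4 is expected to give about 800 nM, estimated within 200 nM to 4000 nM.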

Compound 4, half-maximal inhibitory concentration: 2800 nM
Compound 4: middle estimate off by 3.5-fold (0.54 log units), on the low side; the range from low to high includes it.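

Going by these compounds alone, compound 3 has no number in this assay, so no step to compound 4 can be read. From the compounds shown here alone, whether the phenyl strengthens or weakens inhibition therefore stays open. Nothing shown here offers an explanation for the value of compound 4.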